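This account rests on a few compounds, and the source may have more. Where it says the series, first, only, none or still open, it means among the compounds named here.

Measured so far:
compound 1 `COc1cc(OC)c2c(=O)cc(C(=O)Nc3ccc(-n4cccc4)cc3)[nH]c2c1` — 51800 nM
compound 2 `COC(=O)c1cc(=O)c2cc(NC(=O)Nc3ccc(F)c(Cl)c3)ccc2[nH]1` — > 6350 nM

In a functional assay on UoC-B1 cells (Homo sapiens) for antiproliferative activity, with a stated time of 72 h (a higher number here means that more compound is needed for the effect, a lower number that less compound is needed), compound 1 gives 51800 nM. Compound 2 gives only a limit of the assay, > 6350 nM, and so stands at the limit of > 6350 nM in this assay, at which 1 of the 2 values shown sits, rather than at a number. Compound 3 `COC(=O)c1cc(=O)c2cc(NC(=O)Nc3ccc4c(c3)CCC4)ccc2[nH]1` carries 2,3-dihydro-1H-inden-5-yl in place of 3-chloro-4-fluorophenyl on an amide-type nitrogen. Among the measured compounds shown here, no measured pair shows a change of this kind, so no step beyond the scatter is expected in this assay, and the step written as a step that the limit leaves unreadable from compound 2 to compound 3 is an estimate that stays within it. Compound 3 is therefore expected near 8000 nM, with a range from 3000 nM to 25000 nM, and another limit remains likely.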

Compound 3, half-maximal effective concentration: > 24100 nM
Compound 3 gave a limit, no number (the forecaster's own chance of this, stated with the estimate: 60%); middle value at least 3.0-fold (0.47 log units) from the limit.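

In this assay, compound 2 and compound 3 each give only a limit of the assay, so no step can be read between them. The compounds shown leave open whether 2,3-dihydro-1H-inden-5-yl in place of 3-chloro-4-fluorophenyl shifts the read-out at all.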